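The source may hold more compounds than are shown below. What is called first, only, known or untested is meant among the compounds shown, and "the series" means these compounds.

Measured compounds:
compound 1 `CN(CCC#N)C[C@H]1CN(c2ccc(-n3cc(-c4ccccn4)cn3)c(F)c2)C(=O)O1` – 64500 nM
compound 2 `O=C1O[C@@H](CN2CCCCC2)CN1c1ccc(-n2cc(-c3ccccn3)cn2)c(F)c1` – 219000 nM
compound 3 `O=C1CNC(=O)N1C[C@H]1CN(c2ccc(-n3cc(-c4ccccn4)cn3)c(F)c2)C(=O)O1` – 1630000 nM

In a physicochemical assay for solubility, read by HPLC, with a stated time of 24 h (a higher number here means a more soluble compound, a lower number a less soluble compound), compound 2 stands second highest of the three numbers: compound 1 sits below it by a 3.4-fold higher number from compound 1 to compound 2 (0.53 log units; beyond the scatter), compound 3 above it by a 7.4-fold higher number from compound 2 to compound 3 (0.87 log units; beyond the scatter), and both steps lie beyond the scatter. Compound 1 to compound 3 is the widest span in the set, a 25-fold higher number from compound 1 to compound 3 (1.40 log units; beyond the scatter).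

Compound 4 `CCC(=O)NC[C@H]1CN(c2ccc(-n3cc(-c4ccccn4)cn3)c(F)c2)C(=O)O1` differs from compound 2 in one place: propanoylamino in place of piperidin-1-yl on a saturated chain carbon bound to a saturated ring carbon.

Going by the values given here, no measured step swaps piperidin-1-yl for propanoylamino. The nearest guide is the step from piperidin-1-yl to 2,5-dioxoimidazolidin-1-yl, a 7.4-fold higher number from compound 2 to compound 3 (0.87 log units; beyond the scatter), a modest rise in this assay; both that group and propanoylamino carry a carbonyl and an amide-type nitrogen, whereas the piperidin-1-yl ring carries neither. The step from compound 1, a 3.4-fold higher number from compound 1 to compound 2 (0.53 log units; beyond the scatter), shows the shared core tolerating such changes at this position with shifts well beyond the scatter. A modest rise, a 2.7-fold higher number from compound 2 to compound 4 (0.44 log units; beyond the scatter), is therefore expected for compound 4. Compound 4 is estimated at 600000 nM, with a range of 250000 nM to 1500000 nM.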

Compound 4, solubility: 147000 nM
The estimate for compound 4 lay 4.1-fold (0.61 log units) above the measured number; measured number outside the range, below it.
By their numbers in this assay, from the lowest: compound 1; then compounds 4 and 2 (each within the scatter of the next); then compound 3.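

In this assay, propanoylamino, an open chain with one hydrogen-bond donor, in place of the piperidin-1-yl ring, on a saturated chain carbon bound to a saturated ring carbon, gives no separation beyond the scatter (a 1.5-fold lower number from compound 2 to compound 4 (0.17 log units; within the scatter)). A carbonyl and an amide-type nitrogen are thus not enough on their own to match 2,5-dioxoimidazolidin-1-yl (an 11-fold lower number from compound 3 to compound 4 (1.04 log units; beyond the scatter)), although propanoylamino still stands apart from (2-cyanoethyl)(methyl)amino (a 2.3-fold higher number from compound 1 to compound 4 (0.36 log units; beyond the scatter)). Nothing in hand accounts for these steps.

As far as these compounds go, whether a shorter or longer acyl chain, as in acetylamino or butanoylamino, would stay with compound 4 remains open. So does whether a one-carbonyl ring such as 2-oxopyrrolidin-1-yl, or a carboxylic acid at this place, would come closer to compound 3.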